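Substituted Benzylidene Semicarbazides on a Triazolylpyridine Ether

The source may report more compounds than this note shows. Statements on the series, on what has been measured and on what is new or still open speak of the compounds shown alone.

Compound 1 `CN(C)CCn1cnnc1-c1cc(Oc2ccc(NC(=O)N/N=C/c3cc(C(C)(C)C)cc(C(C)(C)C)c3O)cc2F)ccn1`: 980 nM
Compound 2 `CN(C)CCn1cnnc1-c1cc(Oc2ccc(NC(=O)N/N=C/c3ccccc3)cc2F)ccn1`: 1860 nM
Compound 3 `Cn1ncnc1-c1cc(Oc2ccc(NC(=O)N/N=C/c3ccccc3)cc2F)ccn1`: > 100000 nM

In a functional assay on A549 cells (Homo sapiens) for cytotoxicity, read by MTT assay, with a stated time of 72 h (on this read-out higher numbers stand for weaker inhibition and lower numbers for stronger inhibition), compound 2 gives 1860 nM, the highest of the two numbers reported; the nearest is compound 1 with 980 nM, a gap that lies within the scatter. Compound 3 is reported only as a limit, (the limit of > 100000 nM in this assay, at which 1 of the 3 values shown sits). Within the data shown here, the one measured step, an at least 53-fold higher number from compound 2 to compound 3 (1.73 log units; beyond the scatter), concerns the other end of the molecule and does not touch the change considered here. Compound 4 `CN(C)CCn1cnnc1-c1cc(Oc2ccc(NC(=O)N/N=C/c3cc(Br)c(O)c(Br)c3)cc2F)ccn1` differs from compound 2 by 3,5-dibromo-4-hydroxyphenyl in place of phenyl on a carbon with a double bond to nitrogen. The values of compound 1 and compound 2 show that a 4-hydroxyphenyl bearing two bulky groups gives a number close to that of plain phenyl. A step of no more than the scatter is therefore expected from compound 2 to compound 4, perhaps a slightly lower number, a 1.6-fold lower number from compound 2 to compound 4 (0.19 log units; within the scatter). For compound 4 the estimated value is 1200 nM, with a range from 400 nM to 4000 nM.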

Compound 4, half-maximal inhibitory concentration: > 100000 nM
Compound 4 ended at the assay's limit; the forecaster's own chance of this, stated with the estimate: 5%; at least 83-fold (1.92 log units) between middle value and limit.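

In this assay, replacing phenyl with 3,5-dibromo-4-hydroxyphenyl on a carbon with a double bond to nitrogen gives an at least 53-fold higher number from compound 2 to compound 4 (1.73 log units; beyond the scatter) and shows that this end of the molecule, too, can decide whether a measurable value remains. Compound 2 (1860 nM) and compound 1 (980 nM) both keep measurable values, so a substituted ring at this place is not enough in itself to lose activity; what it carries matters. Compound 4 is reported only as a limit, so the true size of the step stays unknown: the limit of > 100000 nM in this assay, at which 2 of the 4 values shown sit.

The compounds shown leave open whether the two bromine atoms, the hydroxyl group or their combination accounts for the change. A plain 4-hydroxyphenyl, a 3,5-dibromophenyl or a 3,5-dichloro-4-hydroxyphenyl at this place would separate these parts.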